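A few compounds are considered here, and "the series" means these few. Any claim that something is new, unique, unknown or untested is made for them only; others in the source may bear on it.

Compound 2, whose structure is `COC(=O)/C(=C\c1ccc(OC(=O)c2ccc(OC)c(OC)c2)cc1)Sc1ccnc2cc(Cl)ccc12`, is the better of two closely related esters in a functional assay on HL-60 cells (Homo sapiens) for cytotoxicity, read by MTT assay, with a stated time of 24 h (a lower number here means a stronger inhibitor, a higher number a weaker inhibitor), where it gives 5290 nM. Within the data shown here, its partner, compound 1, with structure `COC(=O)/C(=C\c1ccc(OC(=O)c2cc(OC)cc(OC)c2)cc1)Sc1ccnc2cc(Cl)ccc12`, gives 19000 nM in this assay, and the only measured step, a 3.6-fold lower number from compound 1 to compound 2 (0.56 log units; beyond the scatter), shows that rearranging the two methoxy groups on the benzoate ring already shifts the number beyond the scatter. Compound 3, with structure `COC(=O)/C(=C\c1ccc(OC(=O)c2cc(OC)cc(OC)c2OC)cc1)Sc1ccnc2cc(Cl)ccc12`, has not yet been measured. Its structure differs from compound 2 in one spot: 2,3,5-trimethoxyphenyl in place of 3,4-dimethoxyphenyl on a carbonyl carbon. Among the measured compounds shown here, the step from compound 1 to compound 2 is the only guide, and it concerns the same ring, so a step of a similar, modest size is plausible here, but its direction cannot be read from a single pair, and a change within the scatter is as likely as a shift either way. Compound 3 is therefore expected to land near 6500 nM, within a range from 2000 nM to 20000 nM, which corresponds to an expected step of a 1.2-fold higher number from compound 2 to compound 3 (0.09 log units; within the scatter).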

Compound 3, half-maximal inhibitory concentration: 10700 nM
Beside the measured number, compound 3's estimate is 1.6-fold (0.22 log units) below it; low and high end bracket the measured number.
By their numbers in this assay, from the lowest: compound 2; then compounds 3 and 1 (each within the scatter of the next).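

Within this assay, the swap of 3,4-dimethoxyphenyl for 2,3,5-trimethoxyphenyl on the carbonyl carbon gives a 2.0-fold higher number from compound 2 to compound 3 (0.31 log units; beyond the scatter), so compound 2 keeps the lowest number of the three, although the margin only just clears the scatter. The other new comparison isolates a single addition, methoxy in place of hydrogen on an aromatic carbon, and gives a 1.8-fold lower number from compound 1 to compound 3 (0.25 log units; within the scatter); this addition to compound 1 therefore produces no readable change, and the number of methoxy groups alone does not order these compounds, since compound 1 and compound 3 sit within the scatter of each other while compound 2, with the same count as compound 1, stands apart. No supporting measurement is available to explain why these arrangements differ.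

The compounds shown all carry only methoxy groups on this aromatic ring, so it remains open how a hydroxy group, a chlorine or a fluorine there would behave. Also open, as far as these compounds go, is whether the pattern would hold with an amide in place of the ester link or a carboxylic acid in place of the methyl ester.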